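The source may report more compounds than this note shows. Statements on the series, on what has been measured and on what is new or still open speak of the compounds shown alone.

Of the compounds shown here, two of the shared core have been measured in an in vitro assay on BTI-TN-5B1-4 cells for inhibition of Amine oxidase [flavin-containing] A (Homo sapiens), read by Amplex Red, with a stated time of 15 min, tested at 100 uM; on this read-out higher numbers stand for more inhibition at the one concentration tested (going by the name of the read-out) and lower numbers for less inhibition. Compound 1 `C/C(=N/Nc1nc(-c2ccc(C#N)cc2)cs1)c1ccccc1` gives 40%. Compound 2 `C/C(=N/Nc1nc(-c2ccc(C#N)cc2)cs1)c1cccnc1`, which carries pyridin-3-yl in place of phenyl on a carbon with a double bond to nitrogen, gives 40%; the step of no change at the digits printed from compound 1 to compound 2 (within the scatter) lies within the scatter, so compound 2 stands level with compound 1 on the numbers available.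

Compound 3 `C/C(=N/Nc1nc(-c2ccc([N+](=O)[O-])cc2)cs1)c1cccnc1` has not yet been measured. It differs from compound 2 as follows: nitro in place of cyano on an aromatic carbon. Among the measured compounds shown here, the exchange sits on an aromatic carbon of a six-membered aromatic ring of carbon only, a different part of the molecule from the one altered between compound 1 and compound 2. For the measured compounds named here, no measured step touches a cyano or a nitro group, so the only step known, from compound 1 to compound 2, bears on this change only in showing that the number stayed level across one exchange in this assay. The expected step of no change at the digits printed from compound 2 to compound 3 (within the scatter) is therefore none beyond the scatter. Compound 3 is estimated at 40% in this assay, with a range from 20% to 60%.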

Compound 3, a percentage reported as inhibition, at one concentration (the size of the read-out at that concentration, not a potency): "not active" (no number reported)
No number was reported for compound 3; no gap can be computed for the estimate.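

In this assay, among the compounds shown here, compound 3 is recorded as "not active" (no number reported) without a number, so no step from compound 2 to compound 3 can be read. Nothing shown here offers an explanation for this result. The compounds shown leave open how nitro in place of cyano changes inhibition on the shared core.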